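Opening a Piperidine Amide into a Hydroxypentyl Chain

The compounds below may be only part of what the source reports. "The series", "measured", "known", "first", "only" and "open" are said of these compounds alone.

Of the compounds shown here, two built on one shared core have been measured in an assay on HEK293 cells for displacement of a labelled ligand from NPC1-like intracellular cholesterol transporter 1 (Homo sapiens); a higher number here means a weaker inhibitor, a lower number a stronger inhibitor. Compound 1 `CC(C)(C)OC(=O)NC1CCCN(C(=O)CN2CN(c3ccccc3)C3(CCN(C(=O)c4ccc(C(C)(C)C)cc4)CC3)C2=O)C1` gives 4200 nM in this assay. Compound 2 `CC1CCCN(C(=O)CN2CN(c3ccccc3)C3(CCN(C(=O)c4ccc(C(C)(C)C)cc4)CC3)C2=O)C1` gives 12000 nM, the higher of the two numbers, so of the pair compound 2 is the weaker binder. Among the compounds with values here, the one recorded step is a 2.9-fold higher number from compound 1 to compound 2 (0.46 log units; beyond the scatter); it is modest yet clearly beyond the scatter, showing that this end of the molecule responds to what is attached to it.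

Compound 3 `CC(C)(C)c1ccc(C(=O)N2CCC3(CC2)C(=O)N(CC(=O)NCCCCCO)CN3c2ccccc2)cc1` differs from compound 2 in a single place: (5-hydroxypentyl)amino in place of 3-methylpiperidin-1-yl on a carbonyl carbon. Within the data shown here, no measured pair changes the amide partner itself, so the step from compound 1 to compound 2 bears on this change only indirectly, as evidence that groups carrying hydrogen-bond donors and acceptors in this region are tolerated and can lower the number. The expectation is therefore a small step downward, possibly no further than the scatter. Compound 3 is expected to give about 7000 nM, with a likely range from 2500 nM to 20000 nM. The expected step is a 1.7-fold lower number from compound 2 to compound 3 (0.23 log units; within the scatter).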

Compound 3, half-maximal inhibitory concentration: 9400 nM
For compound 3 the middle estimate is 1.3-fold (0.13 log units) below the measured one; measured number inside the range.
By their numbers in this assay, from the lowest: compound 1; then compounds 3 and 2 (each within the scatter of the next).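

In this assay, swapping the whole 3-methylpiperidin-1-yl ring for the open (5-hydroxypentyl)amino chain, with 7 heavy atoms on each side, gives only a 1.3-fold lower number from compound 2 to compound 3 (0.11 log units; within the scatter). The position on this carbonyl carbon therefore accepts a ring or a flexible chain carrying a hydroxyl group and an amide hydrogen, with no measurable difference between the two groups. The earlier step, a 2.9-fold higher number from compound 1 to compound 2 (0.46 log units; beyond the scatter), came from changing a single group on the ring and lay beyond the scatter, so a small edit there registered while this much larger change in shape did not, and nothing available explains that contrast.

On these data alone, it remains open whether the hydroxyl group contributes at all, which a plain pentyl chain, a longer chain, or a chain ending in an amine or a carboxylic acid would test. As far as these compounds go, it is also open whether the (tert-butoxycarbonyl)amino group, which belongs to the lowest number so far, would bring a similar shift if carried on an open chain rather than on the ring.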